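A few compounds are considered here, and "the series" means these few. Any claim that something is new, unique, unknown or untested is made for them only; others in the source may bear on it.

Measured so far:
compound 1 `O=c1nc(-c2ccccc2)c2cc(-c3cccnc3)ccc2[nH]1` gives > 50000 nM
compound 2 `O=c1nc(-c2ccccc2)c2cc(-c3cncnc3)ccc2[nH]1` gives > 50000 nM

Compound 1 and compound 2 share one core and differ only in the ring attached to it. In an ADME assay on L6 cells (Rattus norvegicus) for cytotoxicity, read by fluorescence and resazurin assay, with a stated time of 72 h (a lower number here means that less compound is needed, a higher number that more compound is needed for the effect), compound 1 reaches the limit of the measurement, > 50000 nM, and not a number. In this assay compound 2 likewise stops at a limit, > 50000 nM. The step that the two limits leave unreadable from compound 1 to compound 2 therefore cannot be read as a size or a direction. So compound 2 stands where the assay gives no number, and the limit of > 50000 nM in this assay, at which 2 of the 2 values shown sit, marks where both values rest.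

Compound 3 `O=c1nc(-c2ccccc2)c2cc(-c3cc[nH]n3)ccc2[nH]1` has not been measured. It differs from compound 2 by 1H-pyrazol-3-yl in place of pyrimidin-5-yl on an aromatic carbon. For the measured compounds named here, the only measured step that bears on this change is a step that the two limits leave unreadable from compound 1 to compound 2, and since it is unreadable it offers neither a size nor a direction to carry over. The expectation is that compound 3 will also stop at the limit, the expected step of a number no higher from compound 2 to compound 3 (the limit leaves the size open) meaning no change beyond the scatter. For compound 3 the estimate in this assay is 50000 nM, with a range from 25000 nM to 200000 nM.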

Compound 3, half-maximal effective concentration: > 50000 nM
Compound 3 gave a limit, no number (the forecaster's own chance of this, stated with the estimate: 85%); the middle value sits exactly at the limit.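

In this assay compound 3 gives > 50000 nM, a limit and not a number. The steps among compound 1, compound 2 and compound 3 therefore cannot be read. The compounds shown leave open whether changing the ring on the shared core moves the value at all, because all three rest at one place: the limit of > 50000 nM in this assay, at which 3 of the 3 values shown sit.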